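Hydroxy to dimethylamino on compound 1

A few compounds are considered here, and "the series" means these few. Any claim that something is new, unique, unknown or untested is made for them only; others in the source may bear on it.

In a functional assay on A549 cells (Homo sapiens) for antiproliferative activity, read by MTT assay, with a stated time of 48 h (a lower number here means a stronger inhibitor, a higher number a weaker inhibitor), compound 1 `COc1ccc(C(=O)c2ccc3c(c2)C=CC(C)(C)O3)c(NC(=O)CO)c1` gives 90 nM, the lowest of the three numbers, against compound 2 `COc1ccc(C(=O)c2ccc(OC)c3c2C=CC(C)(C)O3)c(NC(=O)CN)c1` at 420 nM and compound 3 `CNCC(=O)Nc1cc(OC)ccc1C(=O)c1ccc(OC)c2c1C=CC(C)(C)O2` at 1370 nM. Compound 4 `COc1ccc(C(=O)c2ccc3c(c2)C=CC(C)(C)O3)c(NC(=O)CN(C)C)c1` keeps the core of compound 1 but has dimethylamino in place of hydroxy on a saturated chain carbon bound to a carbonyl carbon. For the measured compounds named here, the one measured step that bears on this is methyl in place of hydrogen on an amine nitrogen, a 3.3-fold higher number from compound 2 to compound 3 (0.51 log units; beyond the scatter), modest but beyond the scatter. Its core differs from that of compound 1, so it is only a loose guide. A step to a higher number is expected, an estimated 3.9-fold higher number from compound 1 to compound 4 (0.59 log units; beyond the scatter). Compound 4 is expected at 350 nM, with an estimated range of 100 nM to 1300 nM.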

Compound 4, half-maximal inhibitory concentration: 1160 nM
Compound 4: middle estimate off by 3.3-fold (0.52 log units), on the low side; the measured number falls inside the stated range.
By their numbers in this assay, from the lowest: compound 1; then compound 2; then compounds 4 and 3 (each within the scatter of the next).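

On the core of compound 1, the change from hydroxy to dimethylamino on a saturated chain carbon bound to a carbonyl carbon is costly in this assay, with a 13-fold higher number from compound 1 to compound 4 (1.11 log units; beyond the scatter), a large step. For the compounds shown here, the earlier compounds showed only a modest methyl step on another core, so this is the first direct reading of a change at this place on this core. Nothing measured here accounts for the loss. From the compounds shown here alone, what stays open is whether the loss follows from hydroxy leaving or dimethylamino entering. Methoxy or methylamino at this place on the same core would bear on that.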